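The source may hold more compounds than are shown below. What is called first, only, known or untested is meant among the compounds shown, and "the series" means these compounds.

Measured compounds:
Compound 1, `CC(=O)NCc1cccc(Cn2nc(NS(=O)(=O)c3ccc(Cl)s3)c3ccccc32)c1`, in a physicochemical assay for solubility, read by chemiluminescence, measured as kinetic solubility (on this read-out higher numbers stand for higher solubility and lower numbers for lower solubility), gives >= 117 ug/mL, which is a limit of the assay and not a number.
Compound 2, `CC(=O)NCc1cccc(Cn2nc(NS(=O)(=O)c3ccc(Cl)s3)c3c(Cl)cccc32)c1`, in this assay gives >= 226 ug/mL, again a limit of the assay.
Compound 3, `CC(=O)NCc1cccc(Cn2nc(NS(=O)(=O)c3ccc(Cl)s3)c3c(F)cccc32)c1`, in this assay gives >= 139 ug/mL, also a limit of the assay.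

All three values in this assay are therefore limits, and compound 3 stands on a limit just as the other two do. The steps among them cannot be read for size: a step that the two limits leave unreadable from compound 1 to compound 2, a step that the two limits leave unreadable from compound 1 to compound 3 and a step that the two limits leave unreadable from compound 2 to compound 3 are all left open by the limits, as the limit of >= 117 ug/mL in this assay, at which 1 of the 3 values shown sits, the limit of >= 139 ug/mL in this assay, at which 1 of the 3 values shown sits, and the limit of >= 226 ug/mL in this assay, at which 1 of the 3 values shown sits, show.

Compound 4, `CC(=O)NCc1cccc(Cn2nc(NS(=O)(=O)c3ccc(Cl)s3)c3c(O)cccc32)c1`, differs from compound 3 in one place: hydroxy in place of fluoro on an aromatic carbon. The measured steps that bear on this change are the exchanges at the same aromatic carbon, from hydrogen to chloro, from hydrogen to fluoro and from chloro to fluoro, yet none of them yields a readable size. Going by the values given here, no step in this assay is therefore expected to be resolvable beyond the scatter, and the step that the limit leaves unreadable from compound 3 to compound 4 is an estimate resting on the three limits alone. Compound 4 is expected to give about 150 ug/mL in this assay, within a range from 60 ug/mL to 350 ug/mL.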

Compound 4, solubility: >= 166 ug/mL
Compound 4 was reported as a limit; the forecaster's own chance of this, stated with the estimate: 65%; middle value at least 1.1-fold (0.04 log units) from the limit.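

In this assay compound 4 gives >= 166 ug/mL, which is a limit of the assay and not a number. Its steps to compound 1, compound 2 and compound 3 cannot be read; all four values are limits. The compounds shown leave open how hydrogen, chloro, fluoro and hydroxy on this aromatic carbon compare in this assay.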